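Swapping the ring on the nitrogen: from compound 2 to compound 4

The source may report more compounds than this note shows. Statements on the series, on what has been measured and on what is new or still open speak of the compounds shown alone.

Of the compounds shown here, three of a shared core have been tested in an ADME assay on microsomes from liver (Rattus norvegicus) for metabolic stability, with a stated time of 30 min, tested at 1 uM; on this read-out higher numbers stand for a more stable compound and lower numbers for a less stable compound. Compound 1 `CCC1C(=O)N(C)c2cnc(-n3ccnc3-c3ccccc3)nc2N1c1ccccc1` gives 5%. Compound 2 `CCC1C(=O)N(C)c2cnc(-n3ccnc3-c3ccc(F)cc3)nc2N1C1CCC(F)(F)C1` gives 8% in this assay. Compound 3 `CC[C@@H]1C(=O)N(C)c2cnc(-c3cn[nH]c3-c3nccs3)nc2N1[C@H]1CCOC1` gives 39% in this assay. On these numbers compound 2 stands second highest of the three: its nearest neighbour is compound 1, whose value lies within the usual scatter of compound 2, and the furthest is compound 3, whose value lies beyond the scatter above compound 2. Compound 4 `CCC1C(=O)N(C)c2cnc(-n3ccnc3-c3ccc(F)cc3)nc2N1c1ccc(C#N)cc1` has not yet been measured in this assay. It differs from compound 2 in one place: 4-cyanophenyl in place of 3,3-difluorocyclopentyl on a nitrogen on an aromatic ring in a ring. Among the measured compounds shown here, no step between measured compounds that differ in only one place is available, so the expectation for compound 4 rests on the low values of the two compounds that share its pattern of substitution most closely. Because compound 1 gives 5% and compound 2 gives 8%, compound 4 is expected to remain in the same low region. The step from compound 2 to compound 4 is estimated to be none beyond the scatter, a number 1 percentage points higher from compound 2 to compound 4 (within the scatter). Compound 4 is estimated to give 9% in this assay, within a range from 2% to 25%.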

Compound 4, percent of the compound remaining: 48%
Beside the measured number, compound 4's estimate is 39 percentage points below it, outside the stated range (above it).
By their numbers in this assay, from the lowest: compounds 1 and 2 (each within the scatter of the next); then compounds 3 and 4 (each within the scatter of the next).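

In this assay, the group on this nitrogen, next to the ring atom that bears an ethyl group, proves able to move the read-out a long way: 4-cyanophenyl in place of 3,3-difluorocyclopentyl gives a number 40 percentage points higher from compound 2 to compound 4 (beyond the scatter). The earlier compounds shown here differed from one another in more than one place, so they could not assign any change to this position alone, whereas this pair holds the rest of the molecule fixed, including the 4-fluorophenyl group elsewhere on the shared core. The exchange nevertheless alters several things at once, replacing a five-membered non-aromatic ring of carbon bearing two fluorines with a six-membered aromatic ring bearing a nitrile, and nothing measured here explains why the number rises.

Among the compounds shown here, the single step leaves open whether the aromatic ring, the nitrile or the loss of the 3,3-difluorocyclopentyl group accounts for the rise, and a 4-methoxyphenyl or a 4-pyridyl group on the same nitrogen would help to separate these. Going by these compounds, it also remains open whether a step of this size would recur with a different group in place of the 4-fluorophenyl.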